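The source may report more compounds than this note shows. Statements on the series, on what has been measured and on what is new or still open speak of the compounds shown alone.

The measurements come from a functional assay on RPMI-8226 cells (Homo sapiens) for cytotoxicity, read by sulforhodamine B assay, with a stated time of 48 h, tested at 0.1 uM; a higher number here means a weaker effect of the compound at the concentration tested, a lower number a stronger effect. For the measured compounds named here, compound 2 `COc1ccc(C(=O)/C=C/c2cc(-c3cc(OC)c(OC)c(OC)c3)n[nH]2)cc1OC` gives 79% in this assay, which is the lowest of the two numbers so far; the nearest is compound 1 `COc1cc(-c2cc(/C=C/C(=O)c3ccc(Cl)c(Cl)c3)[nH]n2)cc(OC)c1OC`, which gives 95% in this assay, a value above that of compound 2 by more than the usual scatter. Going by the values given here, the one step on record, a number 16 percentage points lower from compound 1 to compound 2 (beyond the scatter), a modest drop, came from the same part of the molecule that changes next. Compound 3 `COc1cc(-c2cc(/C=C/C(=O)c3ccc(F)c(F)c3)[nH]n2)cc(OC)c1OC` differs from compound 2 in 3,4-difluorophenyl in place of 3,4-dimethoxyphenyl on a carbonyl carbon, so a 3,4-dichlorophenyl-like pair of halogens returns in the form of fluorine. Since the earlier halogen-to-methoxy change lowered the number, the reverse kind of change is expected to raise it, though perhaps by less, given that fluorine is not chlorine. The expected step is a number 9 percentage points higher from compound 2 to compound 3 (within the scatter). Compound 3 is therefore estimated to give 88% in this assay, with a range from 72% to 100%.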

Compound 3, a percentage reported as activity, at one concentration (the size of the read-out at that concentration, not a potency): 90%
Estimate against measurement, compound 3: 2 percentage points below; measured number inside the range.
By their numbers in this assay, from the lowest: compound 2; then compounds 3 and 1 (each within the scatter of the next).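

In this assay, the change on the carbonyl carbon can now be read in both directions: 3,4-difluorophenyl in place of 3,4-dimethoxyphenyl gives a number 11 percentage points higher from compound 2 to compound 3 (beyond the scatter) and so shows that a second halogen pair also stands apart from the methoxy pair. Exchanging one halogen pair for the other gives a number 5 percentage points lower from compound 1 to compound 3 (within the scatter) and so leaves 3,4-difluorophenyl and 3,4-dichlorophenyl indistinguishable at this position. Nothing available explains the difference between the methoxy and halogen compounds.

Still open, going by these compounds, is whether a plain phenyl, a phenyl with a single methoxy group, or a phenyl carrying an amine or a carboxylic acid on this carbonyl carbon would lower the number further. A single tested concentration also leaves open how the compounds compare in potency.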